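Aryl swap on the chain carbon of a vinyl sulfone

The source may report more compounds than this note shows. Statements on the series, on what has been measured and on what is new or still open speak of the compounds shown alone.

Measured so far:
- compound 1 `Cc1ccc(/C=C(\C(=O)c2ccc(Cl)cc2)S(=O)(=O)Cc2ccc(Cl)cc2Cl)s1`: 10000 nM
- compound 2 `O=C(/C(=C\c1ccc(Cl)c([N+](=O)[O-])c1)S(=O)(=O)c1ccc(Br)cc1)c1ccc(Br)cc1`: 10000 nM
- compound 3 `O=C(/C(=C\c1ccc(Cl)c([N+](=O)[O-])c1)Sc1ccc(Br)cc1)c1ccc(Br)cc1`: 10000 nM

In a functional assay on DU-145 cells (Homo sapiens) for inhibition, read by trypan blue exclusion, with a stated time of 96 h (a higher number here means a weaker inhibitor of growth, a lower number a stronger inhibitor of growth), compound 2 gives 10000 nM. For the measured compounds named here, it stands level with compound 1 and compound 3 at the digits printed, so nothing among the measured compounds separates it from its neighbours. Going by the values given here, the only single-point step measured, no change at the digits printed from compound 2 to compound 3 (within the scatter), exchanges the sulfonyl for a sulfanyl and leaves the read-out where it was.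

Compound 4 `O=C(/C(=C\c1ccc(Br)cc1)S(=O)(=O)c1ccc(Br)cc1)c1ccc(Br)cc1` differs from compound 2 at a different place: 4-bromophenyl in place of 4-chloro-3-nitrophenyl on a double-bonded chain carbon bound to a double-bonded chain carbon. Among the compounds with values here, no measured step changes the group on this chain carbon. Compound 1 carries a different ring there and still gives 10000 nM, which is the same level as compound 2. With that, and with the indifference seen in no change at the digits printed from compound 2 to compound 3 (within the scatter), no step beyond the scatter is expected for no change at the digits printed from compound 2 to compound 4 (within the scatter). Compound 4 is therefore estimated at 10000 nM in this assay, with a range from 4000 nM to 20000 nM.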

Compound 4, concentration for 50% growth inhibition: 10000 nM
Beside the measured number, compound 4's estimate shows no gap at the digits printed; the range from low to high includes it.
By their numbers in this assay, from the lowest: compounds 1, 2, 3 and 4 (each within the scatter of the next).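

In this assay, the step at this double-bonded chain carbon bound to a double-bonded chain carbon shows no change at the digits printed from compound 2 to compound 4 (within the scatter) when 4-bromophenyl replaces 4-chloro-3-nitrophenyl. The group that leaves carries hydrogen-bond acceptors and the group that enters carries none, yet this exchange does not separate the two compounds. Nothing measured here offers a reason for this flat read-out. With all the compounds shown level at the digits printed, none provides a more active reference against which to judge a change at this position. As far as these compounds go, it remains open whether a phenyl ring bearing an amine or a carboxylic acid at this place would shift the growth-inhibition read-out.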